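The source may hold more compounds than are shown below. What is called first, only, known or untested is meant among the compounds shown, and "the series" means these compounds.

Three analogues have been measured in an assay for inhibition of Fatty-acid amide hydrolase 1 (Rattus norvegicus); on this read-out higher numbers stand for weaker inhibition and lower numbers for stronger inhibition. Compound 1 `CN(C)C(=O)c1cnc(C(=O)CCc2ccc(Oc3ccccc3)cc2)o1` gives 5.4 nM, compound 2 `O=C(O)c1ccc(-c2cnc(C(=O)CCc3ccc(Oc4ccccc4)cc3)o2)nc1` gives 33 nM, and compound 3 `N#Cc1cnc(C(=O)CCc2ccc(Oc3ccccc3)cc2)o1` gives 0.8 nM, the lowest of the three numbers and beyond the scatter from both others. Compound 4 `COC(=O)c1ccc(-c2cnc(C(=O)CCc3ccc(Oc4ccccc4)cc3)o2)nc1` arises from compound 3 by one change: 5-(methoxycarbonyl)pyridin-2-yl in place of cyano on an aromatic carbon. The step that bears most directly on it runs the other way: a 41-fold lower number from compound 2 to compound 3 (1.62 log units; beyond the scatter); a 6.8-fold lower number from compound 1 to compound 3 (0.83 log units; beyond the scatter) points the same way, cyano giving the lowest number. Compound 4 carries the methyl ester of the acid found in compound 2, so much of that gain is expected to be undone. A large upward step is therefore expected for compound 4, a 25-fold higher number from compound 3 to compound 4 (1.40 log units; beyond the scatter). In this assay compound 4 is estimated at 20 nM, within a range from 5 nM to 80 nM.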

Compound 4, inhibition constant: 54 nM
Compound 4: the middle estimate sits 2.7-fold (0.43 log units) below what was measured; measured number inside the range.
By their numbers in this assay, from the lowest: compound 3; then compound 1; then compounds 2 and 4 (each within the scatter of the next).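

In this assay, this position on the five-membered ring tolerates the 5-(methoxycarbonyl)pyridin-2-yl group poorly compared with the smaller groups, with a 68-fold higher number from compound 3 to compound 4 (1.83 log units; beyond the scatter) against cyano and a 10-fold higher number from compound 1 to compound 4 (1.00 log units; beyond the scatter) against dimethylcarbamoyl. Methyl on the acid oxygen leaves the two compounds indistinguishable, with a 1.6-fold higher number from compound 2 to compound 4 (0.21 log units; within the scatter), so the free acid hydrogen does not set the number of compound 2. No available evidence explains these results.

The compounds shown leave open whether the pyridine ring or the group on it carries the loss. An unsubstituted pyridin-2-yl or a plain phenyl ring at this position would separate the two.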